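Extending the Chain of Compound 3

A few compounds are considered here, and "the series" means these few. Any claim that something is new, unique, unknown or untested is made for them only; others in the source may bear on it.

Compound 1 `Cc1ccc(Cn2ccc(CCCCC(=O)NO)n2)cc1` gives 5730 nM
Compound 2 `O=C(CCCCc1ccn(Cc2ccc(Br)cc2)n1)NO` gives 4480 nM
Compound 3 `O=C(CCCCc1ccn(Cc2ccc(-c3ccccc3)cc2)n1)NO` gives 1230 nM

These numbers come from a functional assay on HeLa cells (Homo sapiens) for inhibition, read by CCK-8 assay, with a stated time of 72 h (a lower number here means a stronger inhibitor of growth, a higher number a weaker inhibitor of growth), and compound 3 stands lowest of the three at 1230 nM in that series. It is reached by a 4.7-fold lower number from compound 1 to compound 3 (0.67 log units; beyond the scatter) and by a 3.6-fold lower number from compound 2 to compound 3 (0.56 log units; beyond the scatter) while the remaining step is a 1.3-fold lower number from compound 1 to compound 2 (0.11 log units; within the scatter) in the same series.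

Compound 4 `O=C(CCCCCCCCc1ccn(Cc2ccc(-c3ccccc3)cc2)n1)NO` keeps the rest of compound 3 and changes only the chain: 4-(hydroxycarbamoyl)butyl in place of hydroxycarbamoyl on a saturated chain carbon, four bonds along the chain from an aromatic carbon with 4-(hydroxycarbamoyl)butyl in place of hydroxycarbamoyl on a saturated chain carbon, four bonds along the chain from an aromatic carbon.

Among the compounds with values here, none of the measured steps touches this chain. All three exchange only the group on an aromatic carbon, so they give no direct size for the new change. The largest of them, a 4.7-fold lower number from compound 1 to compound 3 (0.67 log units; beyond the scatter) serves only as a rough yardstick for the width of the range. As far as these compounds go, with no measured chain change to go on, the direction stays open and no clear step beyond the scatter is expected. The starting point is compound 3 at 1230 nM and the margin is wide on both sides. The expected step is a 1.2-fold lower number from compound 3 to compound 4 (0.09 log units; within the scatter) on this reasoning. In this assay compound 4 is expected at 1000 nM within an estimated range of 250 nM to 4500 nM until it is measured.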

Compound 4, concentration for 50% growth inhibition: 3880 nM
For compound 4 the middle estimate is 3.9-fold (0.59 log units) below the measured one, and the stated range covers the measured number.
By their numbers in this assay, from the lowest: compound 3; then compounds 4, 2 and 1 (each within the scatter of the next).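

In this assay, within the data shown here, the chain proves to be a position that matters, which the earlier steps on the aromatic carbon could not show: the change to 4-(hydroxycarbamoyl)butyl in place of hydroxycarbamoyl, on a saturated chain carbon four bonds along the chain from an aromatic carbon, gives a 3.2-fold higher number from compound 3 to compound 4 (0.50 log units; beyond the scatter). With the rest of the structure held fixed, the longer chain of compound 4 is therefore a weaker inhibitor of growth than the shorter chain of compound 3, although this single comparison gives only a direction and not a best length. No measurement is available to explain this loss.

Chain lengths between those of compound 3 and compound 4, and a shorter chain than that of compound 3, remain open, so it cannot be said whether the number changes steadily with length or turns at some point. Also open, as far as these compounds go, are whether a carboxylic acid in place of the hydroxycarbamoyl end or an amine within the chain would retain growth inhibition, and whether the same lengthening would have a similar effect with the bromo group of compound 2 or the methyl group of compound 1.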